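From Propargyl to 4-Fluorobenzyl: Reading Past a Limit

The compounds below may be only part of what the source reports. "The series", "measured", "known", "first", "only" and "open" are said of these compounds alone.

Within the data shown here, in a functional assay on HUVEC cells (Homo sapiens) for antiproliferative activity, read by MTT assay, with a stated time of 24 h (on this read-out higher numbers stand for weaker inhibition and lower numbers for stronger inhibition), compound 1 `COc1cc(OC)c(-c2coc3cc(OCC=C(C)C)ccc3c2=O)cc1OC` gives 3800 nM and is the only compound so far with a measured number. Compound 2 `C#CCOc1ccc2c(=O)c(-c3cc(OC)c(OC)cc3OC)coc2c1` gives > 10000 nM as a limit and so stands at the limit of > 10000 nM in this assay, at which 2 of the 3 values shown sit, in this small set. Compound 3 `COc1cc(OC)c(-c2coc3cc(OCC(=O)c4cccc(C(F)(F)F)c4)ccc3c2=O)cc1OC` gives > 10000 nM and this too is a limit. Compound 4 `COc1cc(OC)c(-c2coc3cc(OCc4ccc(F)cc4)ccc3c2=O)cc1OC` replaces the propargyl of compound 2 with 4-fluorobenzyl (4-fluorophenyl in place of ethynyl on a saturated chain carbon bound to an oxygen on an aromatic ring). Both an at least 2.6-fold higher number from compound 1 to compound 2 (0.42 log units; beyond the scatter) and an at least 2.6-fold higher number from compound 1 to compound 3 (0.42 log units; beyond the scatter) bear on this change, while a step that the two limits leave unreadable from compound 2 to compound 3 gives no readable size. A small step toward lower numbers is therefore expected, estimated as an at least 1.1-fold lower number from compound 2 to compound 4 (0.04 log units; that floor lies within the scatter) and possibly too small to read. For compound 4 the estimated value is 9000 nM with an expected range of 2500 nM to 30000 nM in this assay here.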

Compound 4, half-maximal inhibitory concentration: > 10000 nM
Compound 4: no number, only a limit (the forecaster's own chance of this, stated with the estimate: 50%); at least 1.1-fold (0.04 log units) between middle value and limit.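

In this assay compound 4 gives > 10000 nM, which is a limit and not a number. Putting 4-fluorophenyl in place of 2-methylprop-1-en-1-yl gives an at least 2.6-fold higher number from compound 1 to compound 4 (0.42 log units; beyond the scatter), so an aromatic ring without a carbonyl on this saturated chain carbon also leaves the read-out short of compound 1. The steps among compound 2, compound 3 and compound 4 cannot be read, since both ends of each are limits: the limit of > 10000 nM in this assay, at which 3 of the 4 values shown sit.

Open, from the compounds shown here alone, is how the 2-methylprop-1-en-1-yl itself matters: whether a longer branched chain or a chain ending in an amine would give a measured number here.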